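Swapping a pyridine arm for a benzyloxy chain

The source may hold more compounds than are shown below. What is called first, only, known or untested is meant among the compounds shown, and "the series" means these compounds.

Three compounds that share one core were measured in an assay on isolated protein for inhibition of mitogen-activated protein kinase kinase kinase 9 (Homo sapiens), tested at 1 uM; a lower number here means less inhibition, a higher number more inhibition at the concentration tested (going by the name of the read-out). Compound 1 `N#CCOc1ccc2c(c1)CCc1c-2c2c(c3c4ccccc4n(CCO)c13)CNC2=O` gives 30%, compound 2 `O=C1NCc2c1c1c(c3c2c2ccccc2n3CCO)CCc2cc(OCC3CC3)ccc2-1` gives 30%, and compound 3 `O=C1NCc2c1c1c(c3c2c2ccccc2n3CCO)CCc2cc(OCc3ccccn3)ccc2-1` gives 36%; all three numbers lie within the scatter of one another, so compound 3 stands level with the other two. The steps of a number 6 percentage points higher from compound 1 to compound 3 (within the scatter) and a number 6 percentage points higher from compound 2 to compound 3 (within the scatter) are both within the scatter. Compound 4 `O=C1NCc2c1c1c(c3c2c2ccccc2n3CCO)CCc2cc(OCCOCc3ccccc3)ccc2-1` differs from compound 3 by (benzyloxy)methyl in place of pyridin-2-yl on a saturated chain carbon bound to an oxygen on an aromatic ring. Among the compounds with values here, no measured step matches this change directly, and the three groups already tried at this place all gave readings within the scatter of each other. A step of about a number 3 percentage points lower from compound 3 to compound 4 (within the scatter) is therefore expected, meaning none beyond the scatter. Compound 4 is estimated to give 33%, within the range 15% to 50%.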

Compound 4, a percentage reported as inhibition, at one concentration (the size of the read-out at that concentration, not a potency): 9%
Compound 4: middle estimate off by 24 percentage points, on the high side; the whole stated range lies above it.
By their numbers in this assay, from the lowest: compound 4; then compounds 1, 2 and 3 (each within the scatter of the next).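

At this place, on a saturated chain carbon bound to an oxygen on an aromatic ring, this assay does respond to the group carried. Within the data shown here, the 2-(benzyloxy)ethyl arm gives a number 27 percentage points lower from compound 3 to compound 4 (beyond the scatter) and a number 21 percentage points lower from compound 2 to compound 4 (beyond the scatter) and a number 21 percentage points lower from compound 1 to compound 4 (beyond the scatter) so the level readings of the earlier compounds do not mean that every group reads alike here. Nothing available explains why this arm reads lower. Going by these compounds, what remains open is whether the longer chain or the benzyl group goes with the lower number, and a 2-methoxyethyl or a plain benzyl group at this place would separate the two.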